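The source may report more compounds than this note shows. Statements on the series, on what has been measured and on what is new or still open speak of the compounds shown alone.

Of the compounds shown here, three from this series have been tested in a functional assay on A549 cells (Homo sapiens) for cytotoxicity, with a stated time of 48 h (on this read-out higher numbers stand for weaker inhibition and lower numbers for stronger inhibition), and a fourth awaits its number. Compound 1 `Cc1ccc2c(=O)cc(/C=C/[S+](C)[O-])oc2c1` gives 2000 nM in this assay, compound 2 `COc1ccc2c(=O)cc(/C=C/[S+](C)[O-])oc2c1` gives 2200 nM, and compound 3 `COc1cccc2oc(/C=C/[S+](C)[O-])cc(=O)c12` gives 3800 nM; the step from compound 3 to compound 2 and that to compound 1 both lie within the scatter, so none of the three can be separated from the others.

Compounds 2 and 1 differ by one change, (methyl in place of methoxy on an aromatic carbon), and the step it made, a 1.1-fold lower number from compound 2 to compound 1 (0.04 log units; within the scatter), is negligible. Compounds 2 and 3 share the same atoms joined differently; the difference between the two cores is not broken down here.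

Compound 4 `Cc1cccc2oc(/C=C/[S+](C)[O-])cc(=O)c12` is the unmeasured partner of compound 3, and the change between them is methyl in place of methoxy on an aromatic carbon. Around its place, the group sits ortho to a fused ring and meta to a fused ring, whereas in the pair of compounds 2 and 1 it sits meta to a fused ring and para to a fused ring, so the two changes are of the same kind rather than the same. Within the data shown here, on the basis of the step of a 1.1-fold lower number from compound 2 to compound 1 (0.04 log units; within the scatter), a similarly small step a 1.1-fold lower number from compound 3 to compound 4 (0.05 log units; within the scatter) is expected here, resting on the single earlier instance only. Compound 4 is therefore estimated at 3400 nM in this assay, expected to fall between 1700 nM and 6800 nM.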

Compound 4, half-maximal inhibitory concentration: 1300 nM
For compound 4 the middle estimate is 2.6-fold (0.42 log units) above the measured one; measured number outside the range, below it.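

In this assay, among these compounds, methyl in place of methoxy on the aromatic carbon ortho to a fused ring and meta to a fused ring gives a 2.9-fold lower number from compound 3 to compound 4 (0.47 log units; beyond the scatter), a modest step and the only instance of this change that stands clear of the usual scatter. Set beside the earlier instance, the new step cannot be told apart from it: the same change on two cores in this assay, a 1.1-fold lower number (0.04 log units; within the scatter) from compound 2 to compound 1 and a 2.9-fold lower number (0.47 log units; beyond the scatter) from compound 3 to compound 4, 2.7-fold (0.42 log units) apart, within the scatter of two such steps. The two instances therefore give no ground for saying that the core alters what this change does, but two instances, one of them within the scatter, do not establish that a step of a given size carries from one core to another, and they cannot separate the effect of the core from that of where the group sits.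

The compounds shown carry only methyl or methoxy on the aromatic ring, so what a chlorine atom, a hydroxyl group or an amine would give at these places remains open. All four also share the same side chain on the shared core, which leaves open what a longer chain or a carboxylic acid in its place would give.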